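This account rests on a few compounds, and the source may have more. Where it says the series, first, only, none or still open, it means among the compounds named here.

Measured compounds in an assay on isolated protein for inhibition of Tryptophan 2,3-dioxygenase (Homo sapiens), read by fluorescence and mass spectrometry, with stated times of 5 min and 15 min; a higher number here means a weaker inhibitor, a lower number a stronger inhibitor:
compound 1, `Nc1oncc1-c1ccccc1`, gives 140 nM
compound 2, `c1ccc(-c2cnoc2)cc1`, gives > 25000 nM, which is a limit of the assay and not a number.

Compound 2 thus stands at the limit of > 25000 nM in this assay, at which 1 of the 2 values shown sits, the weaker end of the two values shown, and nothing more precise is known about it. Compound 3, `NC(=O)c1oncc1-c1ccccc1`, has not yet been measured. It differs from compound 2 by carbamoyl in place of hydrogen on an aromatic carbon. For the measured compounds named here, the only measured step at this place is an at least 170-fold higher number from compound 1 to compound 2 (2.25 log units; beyond the scatter), in which taking away the amino group left compound 2 beyond the limit. That step concerns a different group, amino rather than carbamoyl, so it bears on the present change only loosely. It shows that a small group on this carbon can matter greatly, but not whether carbamoyl would recover any of what amino gave. The expected step is therefore uncertain and is estimated as an at least 3.1-fold lower number from compound 2 to compound 3 (0.49 log units; beyond the scatter). For compound 3 the expected value in this assay is 8000 nM, within a wide range from 800 nM to 25000 nM.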

Compound 3, half-maximal inhibitory concentration: > 25000 nM
Compound 3 was reported as a limit; the forecaster's own chance of this, stated with the estimate: 45%; middle value at least 3.1-fold (0.49 log units) away from the limit.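

In this assay compound 3 gives > 25000 nM, which is a limit of the assay and not a number. Carbamoyl in place of amino gives an at least 170-fold higher number from compound 1 to compound 3 (2.25 log units; beyond the scatter), so adding carbamoyl on this aromatic carbon does not bring back the inhibition seen with amino, and of the three compounds shown, only compound 1, with its amino group, gives a value inside the range of the assay. The step between compound 2 and compound 3 cannot be read, since neither compound has a number to compare: the limit of > 25000 nM in this assay, at which 2 of the 3 values shown sit.

As far as these compounds go, how far compound 2 and compound 3 lie beyond this limit stays unknown, so their order is open, and carbamoyl may have changed nothing or may have changed something too small to bring compound 3 inside the range. The compounds shown also do not tell whether a hydroxyl group, a methylamino group or an aminomethyl group on this carbon would keep any of the inhibition that compound 1 shows in this assay.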